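The source may hold more compounds than are shown below. What is called first, only, known or untested is meant among the compounds shown, and "the series" means these compounds.

In a functional assay on U-937 cells (Homo sapiens) for antiproliferative activity, read by MTT assay, with a stated time of 24 h (on this read-out higher numbers stand for weaker inhibition and lower numbers for stronger inhibition), compound 1 `CNC(=O)c1ccccc1Oc1nc(Nc2ccc(Br)cc2)ncc1Br` gives > 50000 nM, which is a limit and not a number. For the measured compounds named here, compound 2 `CNC(=O)c1ccccc1Oc1nc(Nc2ccccc2OC)ncc1Br` gives 52100 nM, the only number so far. Compound 3 `CNC(=O)c1ccccc1Oc1nc(Nc2cccc(C)c2)ncc1Br` has 3-methylphenyl in place of 2-methoxyphenyl on a nitrogen on an aromatic ring. Going by the values given here, the only measured step bearing on this change is a step that the limit leaves unreadable from compound 1 to compound 2, at the same nitrogen. It supplies no size because the limit of > 50000 nM in this assay, at which 1 of the 2 values shown sits, stands in its place. No direction can be drawn from it, so the expected step, a 1.0-fold lower number from compound 2 to compound 3 (0.02 log units; within the scatter), stays within the scatter. For compound 3 the estimated value is 50000 nM, with an expected range of 25000 nM to 100000 nM.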

Compound 3, half-maximal inhibitory concentration: 15900 nM
The estimate for compound 3 lay 3.1-fold (0.50 log units) above the measured number; measured number below the stated range.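

In this assay, the swap of 2-methoxyphenyl for 3-methylphenyl on the nitrogen gives the first readable size at this position: a 3.3-fold lower number from compound 2 to compound 3 (0.52 log units; beyond the scatter). Set against the 4-bromophenyl group, 3-methylphenyl gives an at least 3.1-fold lower number from compound 1 to compound 3 (0.49 log units; beyond the scatter), a minimum size only, since one end of that step is a limit. The step from compound 1 to compound 2 cannot be read: the limit of > 50000 nM in this assay, at which 1 of the 3 values shown sits.

Open, on these data alone, is whether the number falls further with an amine or a carboxylic acid in place of the methyl of 3-methylphenyl. Also open, as far as these compounds go, is whether the step comes from gaining 3-methylphenyl or from losing 2-methoxyphenyl.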